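The source may report more compounds than this note shows. Statements on the series, on what has been measured and on what is new or still open speak of the compounds shown alone.

Among the compounds with values here, in a functional assay on HT-29 cells (Homo sapiens) for inhibition, read by MTT assay, with a stated time of 120 h (a higher number here means a weaker inhibitor, a lower number a stronger inhibitor), compound 1 `CC(NC(=O)/C=C/c1ccc(NC(=O)Nc2ccc(Cl)c(C(F)(F)F)c2)cc1)c1ccccc1` gives 1060 nM as the lowest number so far. Compound 2 `CC(NC(=O)CCc1ccc(NC(=O)Nc2ccc(Cl)c(C(F)(F)F)c2)cc1)c1ccccc1` gives 26500 nM and compound 3 `O=C(CCc1ccc(NC(=O)Nc2ccc(Cl)c(C(F)(F)F)c2)cc1)NC1CCC1` gives 21300 nM against that, both clearly higher. Unmeasured compound 4 `CC1CN(C(=O)/C=C/c2ccc(NC(=O)Nc3ccc(Cl)c(C(F)(F)F)c3)cc2)CC(C)O1` differs from compound 1 as follows: 2,6-dimethylmorpholin-4-yl in place of (1-phenylethyl)amino on a carbonyl carbon in short, 2,6-dimethylmorpholin-4-yl in place of (1-phenylethyl)amino on a carbonyl carbon. Within the data shown here, the only measured change on this amide nitrogen is a 1.2-fold lower number from compound 2 to compound 3 (0.09 log units; within the scatter) and that pair lacks the double-bonded chain carbon, so it bears only loosely. A modest rise is expected in this assay and the estimated size is a 2.4-fold higher number from compound 1 to compound 4 (0.37 log units; beyond the scatter) with wide uncertainty. Compound 4 is expected at 2500 nM (estimated range 800 nM to 9000 nM).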

Compound 4, half-maximal inhibitory concentration: 9100 nM
Beside the measured number, compound 4's estimate is 3.6-fold (0.56 log units) below it; the whole stated range lies below it.
By their numbers in this assay, from the lowest: compound 1; then compound 4; then compounds 3 and 2 (each within the scatter of the next).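

On a carbonyl carbon whose other neighbour is the double-bonded chain carbon, the amine part clearly affects the result in this assay, with 2,6-dimethylmorpholin-4-yl in place of (1-phenylethyl)amino giving an 8.6-fold higher number from compound 1 to compound 4 (0.93 log units; beyond the scatter) on this change. Within the data shown here, the only earlier step on an amide-type nitrogen, a 1.2-fold lower number from compound 2 to compound 3 (0.09 log units; within the scatter), came from a different replacement in compounds lacking that chain carbon. No supporting measurement bears on the origin of the new step.

Going by these compounds, whether the step follows the ring, its two methyl groups or the missing amide hydrogen remains open. An unsubstituted morpholin-4-yl or a piperazin-1-yl group on this carbonyl carbon would help separate these.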